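This account rests on a few compounds, and the source may have more. Where it says the series, first, only, none or still open, it means among the compounds named here.

Working notes on the series. Compound 1 `O=c1c2ccccc2[se]n1-c1nc(SCc2ccccc2)n[nH]1` reaches only the assay limit in a functional assay on A549 cells (Homo sapiens) for antiproliferative activity, read by CCK-8 assay, with a stated time of 48 h (on this read-out higher numbers stand for weaker inhibition and lower numbers for stronger inhibition), giving > 50000 nM (the limit of > 50000 nM in this assay, at which 1 of the 3 values shown sits). Compound 2 `CC(C)CSc1n[nH]c(-n2[se]c3ccccc3c2=O)n1` gives 37800 nM in this assay, and compound 3 `CCCCCCSc1n[nH]c(-n2[se]c3ccccc3c2=O)n1` gives 20300 nM. The measured steps run an at least 1.3-fold lower number from compound 1 to compound 2 (0.12 log units; that floor lies within the scatter) and an at least 2.4-fold lower number from compound 1 to compound 3 (0.39 log units; beyond the scatter); between the two numbers themselves, a 1.9-fold lower number from compound 2 to compound 3 (0.27 log units; within the scatter). Of the two numbers shown, compound 3 holds the lower one, with compound 2 nearest and within the scatter, while the remaining value is a limit rather than a number.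

Compound 4 `Cc1ccc(CSc2n[nH]c(-n3[se]c4ccccc4c3=O)n2)cc1` differs from compound 3 by 4-methylphenyl in place of pentyl on a saturated chain carbon bound to a sulfur. This change reverses the direction of the step of an at least 2.4-fold lower number from compound 1 to compound 3 (0.39 log units; beyond the scatter), which exchanged phenyl for pentyl at the same carbon and brought at least a modest drop in number, and it also carries 4-methylphenyl rather than plain phenyl. Among the measured compounds shown here, no measured step covers that added methyl. Restoring an aromatic ring at this carbon is therefore expected to push the number back up; compound 4 is expected to show a 2.2-fold higher number from compound 3 to compound 4 (0.35 log units; beyond the scatter), with a real chance that the assay again reports only a limit. Compound 4 is estimated at 45000 nM in this assay, with a range from 20000 nM to 120000 nM.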

Compound 4, half-maximal inhibitory concentration: > 50000 nM
Compound 4: a limit, no number; the forecaster's own chance of this, stated with the estimate: 45%; middle value at least 1.1-fold (0.04 log units) from the limit.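

Compound 4 joins compound 1 as a second compound with an aromatic ring at this carbon that returns only a limit, not a number, in this assay: the limit of > 50000 nM in this assay, at which 2 of the 4 values shown sit.

Against the saturated chains, 4-methylphenyl in place of pentyl gives an at least 2.4-fold higher number from compound 3 to compound 4 (0.39 log units; beyond the scatter), so the gap seen with plain phenyl also holds with the methyl-bearing ring, while 4-methylphenyl in place of isopropyl gives an at least 1.3-fold higher number from compound 2 to compound 4 (0.12 log units; that floor lies within the scatter), whose floor settles nothing. The step that adds the methyl cannot be read, as both of its ends are limits, so the methyl's own contribution stays unknown, and among these four compounds the only numbers belong to the two saturated chains.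

The compounds shown leave open whether a longer chain such as decyl at this carbon would take the number lower than in compound 3, since compound 2 and compound 3 lie within the scatter of each other and give no firm trend with the chain. They also leave open whether a benzyl ring carrying an amine or a carboxylic acid would give a number at all.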